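The source may hold more compounds than are shown below. What is called first, only, known or untested is meant among the compounds shown, and "the series" means these compounds.

In a functional assay on HeLa cells (Homo sapiens) for antiproliferative activity, read by MTT assay, with a stated time of 72 h (on this read-out lower numbers stand for stronger inhibition and higher numbers for weaker inhibition), compound 1 `COc1ncc(-c2ccc3c(c2)NC(=O)CO3)cc1NS(=O)(=O)c1ccc(F)cc1` gives 7110 nM and compound 3 `COc1ncc(-c2ccc3c(c2)N(c2ccccc2)C(=O)CO3)cc1NS(=O)(=O)c1ccc(F)cc1` gives 1530 nM, the lower of these two numbers. The difference, a 4.6-fold lower number from compound 1 to compound 3 (0.67 log units; beyond the scatter), is a modest step beyond the scatter, made at the amide-type nitrogen. Compound 4 `O=C1COc2ccc(-c3cnc(Cl)c(NS(=O)(=O)c4ccc(F)cc4)c3)cc2N1c1ccccc1` differs from compound 3 at another place, with chloro in place of methoxy on an aromatic carbon. Among the measured compounds shown here, no measured step covers this exchange. For the measured compounds named here, the only guide is compound 2 `O=C1COc2ccc(-c3cnc(Cl)c(NS(=O)(=O)c4ccc(F)cc4)c3)cc2N1c1ccc(F)cc1`, which also carries chloro and reads > 40000 nM, a limit and not a number. A weaker result is therefore expected in this assay, with an estimated 6.5-fold higher number from compound 3 to compound 4 (0.82 log units; beyond the scatter). For compound 4 the estimate is 10000 nM, with an expected range of 2500 nM to 40000 nM.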

Compound 4, half-maximal inhibitory concentration: 10300 nM
Compound 4: middle estimate off by 1.0-fold (0.01 log units), on the low side; measured number inside the range.
By their numbers in this assay, from the lowest: compound 3; then compounds 1 and 4 (each within the scatter of the next). At a limit, above all of these: compound 2.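

At the aromatic carbon next to the ring nitrogen, chloro in place of methoxy now has a measured size in this assay, with phenyl held on the amide-type nitrogen: a 6.7-fold higher number from compound 3 to compound 4 (0.83 log units; beyond the scatter). With chloro present in both, hydrogen in place of fluoro on an aromatic carbon gives an at least 3.8-fold lower number from compound 2 to compound 4 (0.58 log units; beyond the scatter), so chloro alone does not set the reading of compound 2. Compound 2 gives a limit and not a number: the limit of > 40000 nM in this assay, at which 1 of the 4 values shown sits.

Going by these compounds, only methoxy and chloro can be compared at this position, so the standing of an amine or a methyl there remains open. Also open, on these data alone, is whether hydrogen in place of fluoro gives a similar step with methoxy present.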